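Fluoro in Place of Methoxy, Made Twice on Two Cores

A few compounds are considered here, and "the series" means these few. Any claim that something is new, unique, unknown or untested is made for them only; others in the source may bear on it.

Compound 1, `COc1ccc(C2=Nn3c(nnc3C(C)c3ccc(-c4ccccc4)c(F)c3)SC2)cc1`, gives 4400 nM in a functional assay on HCT-116 cells (Homo sapiens) for inhibition, read by sulforhodamine B assay, with a stated time of 72 h; on this read-out higher numbers stand for weaker inhibition and lower numbers for stronger inhibition.
Compound 2, `CC(c1ccc(-c2ccccc2)c(F)c1)c1nnc2n1N=C(c1ccc(F)cc1)CS2`, gives 10500 nM in this assay.
Compound 3, `COc1ccc(C2=Nn3c(nnc3C(C)c3ccc(CC(C)C)cc3)SC2)cc1`, gives 4200 nM in this assay.

Of the compounds shown here, three have been measured, and one more waits. Compound 1 and compound 2 share one core and differ in a single place: fluoro in place of methoxy on an aromatic carbon. In this assay this change gave a 2.4-fold higher number from compound 1 to compound 2 (0.38 log units; beyond the scatter).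

Compound 3 carries a different core from compound 1; the difference between the two cores is not broken down here. Their values in this assay lie within the scatter of each other, so nothing separates them on this read-out.

The unmeasured compound 4, `CC(C)Cc1ccc(C(C)c2nnc3n2N=C(c2ccc(F)cc2)CS3)cc1`, stands to compound 3 exactly as compound 2 stands to compound 1: fluoro in place of methoxy on an aromatic carbon. The two place descriptions agree word for word, so this is the same change, now made on the core of compound 3.

Because compound 3 starts from 4200 nM and the same change once gave a 2.4-fold higher number from compound 1 to compound 2 (0.38 log units; beyond the scatter), a step of similar size is expected here, namely a 2.4-fold higher number from compound 3 to compound 4 (0.38 log units; beyond the scatter). Compound 4 is therefore estimated at 10000 nM in this assay, with a plausible range from 4500 nM to 22000 nM; this rests on a single earlier instance of the change, so the range is kept wide.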

Compound 4, half-maximal inhibitory concentration: 12400 nM
For compound 4 the middle estimate is 1.2-fold (0.09 log units) below the measured one, within the range that was stated.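

In this assay, fluoro in place of methoxy gave a 3.0-fold higher number from compound 3 to compound 4 (0.47 log units; beyond the scatter), so the change from 4-methoxyphenyl to 4-fluorophenyl moved the number in the same direction on the core of compound 3 as on the core of compound 1. On these two cores the change carried over in both direction and size, with no difference between the steps beyond what repeated measurement would allow: the same change on two cores in this assay, a 2.4-fold higher number (0.38 log units; beyond the scatter) from compound 1 to compound 2 and a 3.0-fold higher number (0.47 log units; beyond the scatter) from compound 3 to compound 4, 1.2-fold (0.09 log units) apart, within the scatter of two such steps. This does not show that the step would hold on a third core: the comparison rests on two pairs, read on one cell line in one assay, and it gives no reason for the step.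

The compounds shown leave open whether another group in the same place, such as chloro, hydroxyl or an amine, would give numbers closer to those of the methoxy compounds or to those of the fluoro compounds on either core. They also leave open whether the step seen in this assay would appear on another cell line.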